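A few compounds are considered here, and "the series" means these few. Any claim that something is new, unique, unknown or untested is made for them only; others in the source may bear on it.

Compound 1 `COc1ccc(-c2cc3ccccc3nc2/C=C/C(=O)c2ccc(N)cc2)cc1`: 7510 nM
Compound 2 `COc1ccc(-c2cc3ccccc3nc2/C=C/C(=O)c2ccccn2)cc1`: 740 nM
Compound 3 `COc1ccc(-c2cc3ccccc3nc2/C=C/C(=O)c2cnc(N)nc2C)cc1`: > 10000 nM

In a functional assay on MDA-MB-231 cells (Homo sapiens) for antiproliferative activity, read by XTT assay, with a stated time of 72 h (on this read-out lower numbers stand for stronger inhibition and higher numbers for weaker inhibition), compound 1 gives 7510 nM, the higher of the two plain numbers, while compound 2 gives 740 nM. Compound 3 reaches only a limit of the assay, > 10000 nM, which is the limit of > 10000 nM in this assay, at which 1 of the 3 values shown sits. Compound 4 `COc1ccc(-c2cc3ccccc3nc2/C=C/C(=O)c2c[nH]c3ccccc23)cc1` differs from compound 1 in one place: 1H-indol-3-yl in place of 4-aminophenyl on a carbonyl carbon. Three measured steps change the group on that same carbonyl carbon: a 10-fold lower number from compound 1 to compound 2 (1.01 log units; beyond the scatter); an at least 1.3-fold higher number from compound 1 to compound 3 (0.12 log units; that floor lies within the scatter); an at least 13-fold higher number from compound 2 to compound 3 (1.13 log units; beyond the scatter). Exchanges here therefore run from a large fall in the number to a limit, with no clear rule tying the kind of ring to the direction. For compound 4 a step of a 2.5-fold lower number from compound 1 to compound 4 (0.40 log units; beyond the scatter) is expected, with wide uncertainty. Compound 4 is estimated at 3000 nM, most likely between 600 nM and 15000 nM.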

Compound 4, half-maximal inhibitory concentration: > 10000 nM
Compound 4: a limit, no number; the forecaster's own chance of this, stated with the estimate: 15%; middle value at least 3.3-fold (0.52 log units) from the limit.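

In this assay, the two-ring 1H-indol-3-yl on the carbonyl carbon brings no clear improvement over 4-aminophenyl, with an at least 1.3-fold higher number from compound 1 to compound 4 (0.12 log units; that floor lies within the scatter). Measured against pyridin-2-yl, the loss is large, with an at least 13-fold higher number from compound 2 to compound 4 (1.13 log units; beyond the scatter). Compound 3 and compound 4 both give limits, so the step between them cannot be read, and a second group now sits at that ceiling: the limit of > 10000 nM in this assay, at which 2 of the 4 values shown sit.

Left open is whether pyridin-3-yl, pyridin-4-yl or plain phenyl on the carbonyl carbon would match compound 2 in this assay.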